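The compounds below may be only part of what the source reports. "The series", "measured", "known", "first", "only" and "open" are said of these compounds alone.

Measured so far:
Compound 1 `Cc1ccc2cccc(NS(=O)(=O)c3ccccc3[N+](=O)[O-])c2n1` gives 3800 nM in an assay on isolated protein (HUVEC cells) for inhibition of transcription factor p65 (Homo sapiens); on this read-out higher numbers stand for weaker inhibition and lower numbers for stronger inhibition.
Compound 2 `COc1cc(NS(=O)(=O)c2ccc(C)cc2)c2nc(C)ccc2c1` gives no number but only > 10000 nM, which is the limit of > 10000 nM in this assay, at which 1 of the 3 values shown sits.
Compound 3 `Cc1ccc2cccc(NS(=O)(=O)c3ccccc3N)c2n1` gives 2800 nM in this assay.

Of the two numbers, compound 3 has the lower one, but its gap to compound 1 lies within the scatter, so the two cannot be ranked against each other. Going by the values given here, the only step measured between compounds that differ in a single place is a 1.4-fold lower number from compound 1 to compound 3 (0.13 log units; within the scatter). Compound 4 `Cc1ccc2cccc(NS(=O)(=O)c3ccc(Br)s3)c2n1` differs from compound 3 by 5-bromothiophen-2-yl in place of 2-aminophenyl on a sulfonyl sulfur. Among the compounds with values here, the measured step also altered the group on the sulfonyl sulfur, yet it changed just one substituent on that ring and stayed within the scatter, whereas here the whole ring is exchanged, and no measured pair covers such an exchange. With nothing pointing in either direction, the expectation for compound 4 is a number close to that of compound 3, with a wide range. The expected step is a 1.1-fold higher number from compound 3 to compound 4 (0.03 log units; within the scatter). For compound 4 the estimate in this assay is 3000 nM, expected to fall between 700 nM and 13000 nM.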

Compound 4, half-maximal inhibitory concentration: 1400 nM
The estimate for compound 4 lay 2.1-fold (0.33 log units) above the measured number; measured number inside the range.
By their numbers in this assay, from the lowest: compounds 4, 3 and 1 (each within the scatter of the next, the first and the last beyond it). At a limit, above all of these: compound 2.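

In this assay the exchange of 2-aminophenyl for 5-bromothiophen-2-yl on a sulfonyl sulfur gives a 2.0-fold lower number from compound 3 to compound 4 (0.30 log units; within the scatter) and so stays inside the usual spread of repeat measurements. The earlier step changed one substituent on the ring at this position, whereas this one replaces the whole ring, a six-membered carbon ring giving way to a five-membered ring with a hetero atom, and still produces no difference that can be told from the scatter. Compound 4 at 1400 nM and compound 1 at 3800 nM do lie beyond the scatter of each other, but nothing shown here accounts for that gap.

On these data alone, this exchange alters the ring and brings in bromine at once, so the share of each stays open. A thiophen-2-yl without bromine, or with chlorine in its place, would separate the two.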